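This account rests on a few compounds, and the source may have more. Where it says the series, first, only, none or still open, it means among the compounds named here.

Measured so far:
- compound 1 `CC1=NN(S(=O)(=O)c2ccc([N+](=O)[O-])cc2)C(c2cc(Br)cc(Br)c2O)C1`: 50000 nM
- compound 2 `CC1=NN(S(=O)(=O)c2ccc(C)cc2)C(c2cc(Br)cc(Br)c2O)C1`: 51200 nM

Of the compounds shown here, two sharing one core have been tested in a functional assay on PC-3 cells (Homo sapiens) for cytotoxicity, read by MTT assay, with a stated time of 48 h; on this read-out higher numbers stand for weaker inhibition and lower numbers for stronger inhibition. Among the measured compounds shown here, compound 1 gives 50000 nM and compound 2 gives 51200 nM, and the only change between them, a methyl in place of a nitro on an aromatic carbon, moves the number by a 1.0-fold higher number from compound 1 to compound 2 (0.01 log units; within the scatter), which is within the scatter. On these two numbers compound 1 stands lowest, but its gap to compound 2 is too small to count as a difference.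

Compound 3 `CC1=NN(S(=O)(=O)c2ccc([N+](=O)[O-])cc2)C(c2cc(Cl)ccc2O)C1` differs from compound 1 in a different place: 5-chloro-2-hydroxyphenyl in place of 3,5-dibromo-2-hydroxyphenyl on a saturated ring carbon. For the measured compounds named here, no measured step touches this position, so nothing among the measured compounds says how large a step to expect in this assay or in which direction. Going by the values given here, the one measured step, from the nitro to the methyl, left the number where it was, which is the only hint that this core tolerates small changes without much movement.

With that, compound 3 is expected to land near compound 1, a step of no change at the digits printed from compound 1 to compound 3 (within the scatter), giving an estimate of 50000 nM with a range from 15000 nM to 160000 nM.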

Compound 3, half-maximal inhibitory concentration: 44200 nM
The estimate for compound 3 lay 1.1-fold (0.05 log units) above the measured number, within the range that was stated.
By their numbers in this assay, from the lowest: compounds 3, 1 and 2 (each within the scatter of the next).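

In this assay, putting 5-chloro-2-hydroxyphenyl in place of 3,5-dibromo-2-hydroxyphenyl on the saturated ring carbon gives a 1.1-fold lower number from compound 1 to compound 3 (0.05 log units; within the scatter), so this position now has a measured step of its own, and that step stays within the scatter. The exchange is more than a swap of one halogen for another: the group that leaves carries two bromine atoms, the group that enters carries one chlorine atom, and the aromatic ring and its hydroxy group remain in both, yet the number shows no real change. Nothing available bears on why this exchange leaves the number where it is.

The compounds shown leave open whether this position responds to any larger change, since both groups tested here are halogen-bearing 2-hydroxyphenyl groups, and an unsubstituted phenyl, a methoxy in place of the hydroxy, or an aromatic ring carrying an amine or a carboxylic acid could behave differently. Among the compounds shown here, they also leave open whether any change to the shared core can bring the number well below that of compound 1, as neither step so far has moved it beyond the scatter.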